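This account rests on a few compounds, and the source may have more. Where it says the series, first, only, none or still open, it means among the compounds named here.

Of the compounds shown here, two built on a shared core have been tested in a functional assay on MDA-MB-231 cells (Homo sapiens) for inhibition, read by MTT assay, with a stated time of 72 h; on this read-out higher numbers stand for weaker inhibition and lower numbers for stronger inhibition. Compound 1 `O=C(CSc1nc(Nc2ccccc2)c2ccccc2n1)Nc1ccccc1Cl` gives 24400 nM, and compound 2 `C=CC(=O)Nc1cccc(NC(=O)CSc2nc(Nc3ccccc3F)c3ccccc3n2)c1` gives 18700 nM; the two numbers lie within the usual scatter of each other, so neither stands apart. Compound 3 `C=CC(=O)Nc1cccc(NC(=O)CSc2nc(Nc3ccccc3C)c3ccccc3n2)c1` differs from compound 2 by methyl in place of fluoro on an aromatic carbon. Among the compounds with values here, since no measured pair shows this kind of change, the step of a 1.1-fold lower number from compound 2 to compound 3 (0.04 log units; within the scatter) is expected to be small, in no clear direction, and probably within the scatter. Compound 3 is therefore estimated at 17000 nM, between 7000 nM and 40000 nM.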

Compound 3, half-maximal inhibitory concentration: 20400 nM
Estimate against measurement, compound 3: 1.2-fold (0.08 log units) below; measured number inside the range.
By their numbers in this assay, from the lowest: compounds 2, 3 and 1 (each within the scatter of the next).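

In this assay, within the data shown here, the first measured pair for this change shows that methyl in place of fluoro, on an aromatic carbon ortho to a large group, gives a 1.1-fold higher number from compound 2 to compound 3 (0.04 log units; within the scatter). At this position, then, 2-fluorophenyl and 2-methylphenyl cannot be told apart on this read-out. No measured property of either group bears on this result. Still open, going by these compounds, is whether an amine or a carboxylic acid at the same position would stay within the scatter or move the number clearly.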